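This account rests on a few compounds, and the source may have more. Where it says the series, first, only, none or still open, it means among the compounds named here.

Working notes on the series. Of the compounds shown here, two carry the shared core and have been measured: compound 1 `O=C(CSc1nc(Nc2ccccc2)c2ccccc2n1)Nc1ccccc1Cl` and compound 2 `CCc1ccc(NC(=O)CSc2nc(Nc3ccccc3)c3ccccc3n2)cc1`. For the measured compounds named here, in a functional assay on PC-3 cells (Homo sapiens) for inhibition, read by MTT assay, with a stated time of 72 h (a higher number here means a weaker inhibitor, a lower number a stronger inhibitor), compound 2 gives 17900 nM, and compound 1 gives 14600 nM; the two numbers lie within the scatter of each other, so compound 2 stands level with the only other measured compound. Going by the values given here, the single measured step, a 1.2-fold higher number from compound 1 to compound 2 (0.09 log units; within the scatter), varies the aryl group on the amide-type nitrogen and stays within the scatter.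

Compound 3 `O=C(CSc1nc(Nc2ccccc2)c2ccccc2n1)Nc1ccc(F)c(Cl)c1` is not yet measured. It differs from compound 2 by 3-chloro-4-fluorophenyl in place of 4-ethylphenyl on an amide-type nitrogen. The measured step bears on this change, since it alters the same aryl group on the amide-type nitrogen and gave no movement beyond the scatter. For compound 3 the expected step is therefore a 1.2-fold lower number from compound 2 to compound 3 (0.08 log units; within the scatter), no movement beyond the scatter in either direction. Compound 3 is estimated at 15000 nM in this assay, with a range from 6000 nM to 38000 nM.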

Compound 3, half-maximal inhibitory concentration: 15500 nM
Compound 3: the middle estimate sits 1.0-fold (0.01 log units) below what was measured; measured number inside the range.
By their numbers in this assay, from the lowest: compounds 1, 3 and 2 (each within the scatter of the next).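

In this assay, putting 3-chloro-4-fluorophenyl in place of 4-ethylphenyl on the amide-type nitrogen gives a 1.2-fold lower number from compound 2 to compound 3 (0.06 log units; within the scatter), and putting it in place of 2-chlorophenyl gives a 1.1-fold higher number from compound 1 to compound 3 (0.03 log units; within the scatter). The three aryl groups at this place now stand level, so a group carrying both fluorine and chlorine does not separate from one carrying a single chlorine or an all-carbon ethyl group. No supporting measurement bears on why these numbers stay level.

Going by these compounds, whether anything at this place can move the number beyond the scatter stays open, as all three compounds carry a substituted phenyl there. A phenyl bearing a carboxylic acid or an amine, or a longer alkyl chain in place of the aryl group, would test this.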